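The compounds below may be only part of what the source reports. "The series", "measured", "known", "first", "only" and "open" are said of these compounds alone.

Measured in an ADME assay (liver) for metabolic stability, with Liver microsome (Rattus norvegicus) as the target, using microsomes; on this read-out lower numbers stand for slow clearance and higher numbers for fast clearance:
- compound 1 `O=C(O)c1csc(-n2nc(-c3ccccc3)c3cccnc32)n1`: 65 mL/min/kg
- compound 2 `O=C(O)c1csc(-n2nc(-c3ccccc3)c3ccncc32)n1`: 69 mL/min/kg
- compound 3 `O=C(O)c1csc(-n2nc(-c3ccc(F)cc3)c3ccccc32)n1`: 278 mL/min/kg

Compound 3 has the highest of the three values, beyond the scatter of both others. Compound 4 `O=C(O)c1csc(-n2nc(-c3ccsc3)c3ccccc32)n1` carries thiophen-3-yl in place of 4-fluorophenyl on an aromatic carbon. For the measured compounds named here, no measured pair differs in one place only, so the data give no direct read on this change. The shared core stays as in compound 3, so a value in its high range remains expected, with no step beyond the scatter, slightly downward if anything: a 1.4-fold lower number from compound 3 to compound 4 (0.14 log units; within the scatter) is the expected step. For compound 4 the estimated clearance is 200 mL/min/kg, with an expected range of 100 mL/min/kg to 400 mL/min/kg.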

Compound 4, clearance: 190 mL/min/kg
Compound 4: the middle estimate sits 1.1-fold (0.02 log units) above what was measured, within the range that was stated.
By their numbers in this assay, from the lowest: compounds 1 and 2 (each within the scatter of the next); then compounds 4 and 3 (each within the scatter of the next).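

Thiophen-3-yl in place of 4-fluorophenyl gives a 1.5-fold lower number from compound 3 to compound 4 (0.17 log units; within the scatter) in this assay, the first step in the series between compounds that differ in one place. At this position, a five-membered aromatic ring with sulfur and a six-membered aromatic ring of carbon only are therefore not separated on this read-out. No available measurement offers an explanation for this result.

Going by these compounds, whether an amine or a longer alkyl chain at this position would give a step beyond the scatter stays open. Compound 1 and compound 2 differ from compound 3 in more than one place, so the gap to them cannot be assigned to any single change.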